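The compounds below may be only part of what the source reports. "The series", "measured", "known", "first", "only" and "open" are said of these compounds alone.

Measured compounds:
- compound 1, `CO[C@H]1CC[C@@H](CNc2cc(NCc3cnccc3C(F)(F)F)ncc2C#N)CC1`, in an assay on isolated protein for inhibition of protein kinase C theta type (Homo sapiens), read by TR-FRET, with a stated time of 2 h (on this read-out lower numbers stand for stronger inhibition and higher numbers for weaker inhibition), gives 70 nM
- compound 2, `N#Cc1cnc(NCc2cnccc2C(F)(F)F)cc1N[C@H]1CC[C@@H](c2nc[nH]n2)CC1`, gives 34 nM
- compound 3, `N#Cc1cnc(NCc2ccccc2)cc1N[C@H]1CC[C@@H](O)CC1`, gives 7000 nM

Among these three numbers compound 1 stands second highest. Its nearest neighbour is compound 2, whose lower number lies just beyond the usual scatter of this assay; the furthest is compound 3, whose much higher number lies far beyond it. Going by the values given here, no step between two measured compounds that differ in only one place is available, so each gap can only be read off the values themselves.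

Compound 4, `CC1(C)[C@@H](C(N)=O)C[C@H]1Nc1cc(NCc2cnccc2C(F)(F)F)ncc1C#N`, has not yet been measured. It differs from compound 1 in one place: 3-carbamoyl-2,2-dimethylcyclobutyl in place of (4-methoxycyclohexyl)methyl on a nitrogen on an aromatic ring. The group that leaves and the group that enters are of the same size, but the six-membered ring with its methoxy gives way to a four-membered ring carrying an amide, and the group now sits directly on the nitrogen rather than through a single carbon.

Among the compounds with values here, with no measured step of this kind to lean on, a modest shift towards a higher number is expected, at the edge of the scatter, as a 2.1-fold higher number from compound 1 to compound 4 (0.33 log units; beyond the scatter). Compound 4 is therefore estimated at 150 nM, within 40 nM to 600 nM.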

Compound 4, half-maximal inhibitory concentration: 1.4 nM
The estimate for compound 4 lay 110-fold (2.03 log units) above the measured number; measured number below the stated range.
By their numbers in this assay, from the lowest: compound 4; then compound 2; then compound 1; then compound 3.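

In this assay the swap of (4-methoxycyclohexyl)methyl for 3-carbamoyl-2,2-dimethylcyclobutyl on a nitrogen on an aromatic ring gives a 50-fold lower number from compound 1 to compound 4 (1.70 log units; beyond the scatter), so the group at this position can move the number a long way even when the heavy-atom count stays the same. The swap alters several things at once: the six-membered ring becomes a four-membered one, the methoxy gives way to a carbamoyl that brings a hydrogen-bond donor, and the single carbon linking the ring to the nitrogen disappears. No measurement shown explains the drop, and this one step cannot say which of these alterations matters most.

On these data alone, it remains open whether the two methyl groups on the cyclobutyl ring contribute to the step. As far as these compounds go, it is also open how a carboxylic acid or an amine in place of the carbamoyl would read.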